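Pyridazinyl urea series: methyl and chloro changes at the limit

The compounds below may be only part of what the source reports. "The series", "measured", "known", "first", "only" and "open" are said of these compounds alone.

Compound 1 `O=C(Nc1nc2ccc(F)cc2s1)N1CCN(c2ccc(Cl)nn2)CC1`, compound 2 `Cc1cc(N2CCN(C(=O)Nc3nc4ccc(F)cc4s3)CC2)nnc1Cl` and compound 3 `O=C(Nc1nc2ccc(F)cc2s1)N1CCN(c2cccnn2)CC1` share one core. In an assay on HEK293 cells for inhibition of transient receptor potential cation channel subfamily V member 1 (Homo sapiens), read by FLIPR, at pH 5.5 (a higher number here means a weaker inhibitor, a lower number a stronger inhibitor), compound 1 gives > 10000 nM, a limit of the assay and not a number. In this assay compound 2 gives > 10000 nM, also a limit. In this assay compound 3 gives > 10000 nM, again a limit. The change methyl in place of hydrogen on an aromatic carbon gives a step that the two limits leave unreadable from compound 1 to compound 2, unreadable because the limit of > 10000 nM in this assay, at which 3 of the 3 values shown sit, holds all three values. The cores of compound 1 and compound 3 differ by hydrogen in place of chloro on an aromatic carbon. Compound 4 `Cc1ccnnc1N1CCN(C(=O)Nc2nc3ccc(F)cc3s2)CC1` arises from compound 3 by methyl in place of hydrogen on an aromatic carbon, the same kind of change as from compound 1 to compound 2, but here ortho to a large group rather than ortho to a chloro group and meta to a large group. From the limit shown by compound 3, the expected step is a step that the limit leaves unreadable from compound 3 to compound 4. Compound 4 is expected at 20000 nM, between 8000 nM and 60000 nM, most likely again as a limit.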

Compound 4, half-maximal inhibitory concentration: > 25000 nM
Compound 4 gave a limit, no number; the forecaster's own chance of this, stated with the estimate: 85%; middle value at least 1.2-fold (0.09 log units) from the limit.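

In this assay, for the compounds shown here, compound 4 gives a limit, as compounds 1, 2 and 3 do, so no step among the four can be read. The compounds shown leave open whether methyl in place of hydrogen changes inhibition at all.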